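A few compounds are considered here, and "the series" means these few. Any claim that something is new, unique, unknown or untested is made for them only; others in the source may bear on it.

Working notes on the series. Compound 1 `CCCn1c(SCc2cccc(OC)c2)nc2c1c(=O)[nH]c(=O)n2C` gives 34.2% in a functional assay on MGC-803 cells (Homo sapiens) for inhibition, read by MTT assay, with a stated time of 48 h, tested at 20 uM; a higher number here means more inhibition at the concentration tested (going by the name of the read-out), a lower number less inhibition. Compound 2 `Cn1cnc2c1c(=O)n(CC(=O)OC(C)(C)C)c(=O)n2C` gives 17.2% in this assay; this is the lowest of the two numbers, and compound 1 lies above it by a gap beyond the usual scatter. Compound 3 `Cn1cnc2c1c(=O)n(CC(=O)O)c(=O)n2C` is not yet measured. The change from compound 2 to compound 3 is hydrogen in place of tert-butyl on an oxygen next to a carbonyl group. For the measured compounds named here, no measured pair shares this change, so the step from compound 2 to compound 3 is expected to be small, a number 4.2 percentage points lower from compound 2 to compound 3 (within the scatter), likely within the scatter and if anything downward. Compound 3 is therefore expected to give about 13%, in the range 2% to 28%.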

Compound 3, a percentage reported as inhibition, at one concentration (the size of the read-out at that concentration, not a potency): 0.8%
Beside the measured number, compound 3's estimate is 12.2 percentage points above it, outside the stated range (below it).
By their numbers in this assay, from the lowest: compound 3; then compound 2; then compound 1.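

Hydrogen in place of tert-butyl on an oxygen next to a carbonyl group gives a number 16.4 percentage points lower from compound 2 to compound 3 (beyond the scatter) in this assay, the first single-place step in the series. This position is therefore not indifferent to what it carries: tert-butoxycarbonyl to carboxy changes the read-out by more than the usual scatter. No measurement at hand bears on the cause of this step.

As far as these compounds go, whether a methyl ester or an amide at this position would stay with compound 2 or fall with compound 3 remains open. So does whether the same change would give a similar step on the core of compound 1.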